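This account rests on a few compounds, and the source may have more. Where it says the series, first, only, none or still open, it means among the compounds named here.

Measured compounds:
Compound 1, `Cc1cc(C)c2sc(NC(=O)c3ccc(C#N)cc3)nc2c1`: 0.48 ug/mL
Compound 2, `Cc1cc(C)c2sc(NC(=O)c3ccc(C(F)(F)F)cc3)nc2c1`: 0.45 ug/mL
Compound 3, `COc1ccc2sc(NC(=O)c3ccc(C(F)(F)F)cc3)nc2c1`: > 10 ug/mL

Compounds 1 and 2 share one core and carry a nitrile or a trifluoromethyl on the benzamide. In a functional assay on MDA-MB-231 cells (Homo sapiens) for antiproliferative activity, read by sulforhodamine B assay (on this read-out higher numbers stand for weaker inhibition of growth and lower numbers for stronger inhibition of growth), compound 1 gives 0.48 ug/mL and compound 2 gives 0.45 ug/mL. The change from compound 2 to compound 1 is cyano in place of trifluoromethyl on an aromatic carbon, and it gives a 1.1-fold higher number from compound 2 to compound 1 (0.03 log units; within the scatter).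

Compound 3 has a different core; the difference between the two cores is not broken down here. In this assay compound 3 gives only > 10 ug/mL, which is a limit of the assay and not a number. Compound 3 sits at the limit of > 10 ug/mL in this assay, at which 1 of the 3 values shown sits.

Compound 4, `COc1ccc2sc(NC(=O)c3ccc(C#N)cc3)nc2c1`, is not yet measured. It differs from compound 3 by cyano in place of trifluoromethyl on an aromatic carbon, the same change as from compound 2 to compound 1. Because that change gave a 1.1-fold higher number from compound 2 to compound 1 (0.03 log units; within the scatter), the step from compound 3 to compound 4 is expected to be about a step that the limit leaves unreadable from compound 3 to compound 4 in this assay. Compound 4 is therefore estimated at about 12 ug/mL, between 4 ug/mL and 40 ug/mL, most likely again only a limit.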

Compound 4, concentration for 50% growth inhibition: > 10 ug/mL
Compound 4: no number, only a limit; the forecaster's own chance of this, stated with the estimate: 70%; the middle value does not contradict the limit.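

No step can be read from compound 3 to compound 4, as each gives only a limit of the assay and not a number, and both stand at the same one: the limit of > 10 ug/mL in this assay, at which 2 of the 4 values shown sit.

The compounds shown leave open whether cyano in place of trifluoromethyl makes any difference on the core that compound 3 and compound 4 share.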